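The source may report more compounds than this note shows. Statements on the series, on what has been measured and on what is new or still open speak of the compounds shown alone.

Measured compounds:

Compound 1, `CC1(C)C(=O)Nc2ccc(OCc3ccc(F)cc3)cc21`: "not active" (no number reported)
Compound 2, `O=C1Nc2ccc(OCc3cccc(Cl)c3)cc2C1=O`: 93%

The study is read in an assay on cells for inhibition of Amine oxidase [flavin-containing] B (Homo sapiens), read by fluorescence, with stated times of 30 min and 15 min, tested at 1 uM (on this read-out higher numbers stand for more inhibition at the one concentration tested (going by the name of the read-out) and lower numbers for less inhibition), where compound 2 gives 93%. Compound 1 is reported in this assay only as "not active" (no number reported), with no number behind it. For the measured compounds named here, compound 2 therefore stands alone: it is the only entry with a number, and the one further entry carries no number at all, so no step between measured compounds can be given.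

The next compound, compound 3, `O=C1Nc2ccc(OCc3ccc(Cl)c(Cl)c3)cc2C1=O`, has not been measured. It differs from compound 2 by chloro in place of hydrogen on an aromatic carbon. Going by the values given here, since the data hold no step of this kind, the expectation for compound 3 rests on compound 2 alone, which gives 93% in this assay. The step of a number 3 percentage points lower from compound 2 to compound 3 (within the scatter) is expected to stay within the usual scatter, in no particular direction. Compound 3 is therefore estimated at 90%, with a range from 75% to 99%.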

Compound 3, a percentage reported as inhibition, at one concentration (the size of the read-out at that concentration, not a potency): 95.7%
Beside the measured number, compound 3's estimate is 5.7 percentage points below it; low and high end bracket the measured number.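

With chloro in place of hydrogen on this aromatic carbon, ortho to a chloro group and para to a large group, this assay shows a number 2.7 percentage points higher from compound 2 to compound 3 (within the scatter). For the compounds shown here, this is the first step that can be read, and it shows that the position takes a chloro group with no difference from compound 2 that stands out from the scatter, though a reading at one concentration is not a potency. No measurement given here bears on why the two compounds read alike.

The compounds shown leave open how a methoxy group, a nitrile or a trifluoromethyl group would read on this same carbon. They also leave open which of the several differences between compound 1 and compound 2 goes with the "not active" report for compound 1.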